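The compounds below may be only part of what the source reports. "The series", "measured", "known", "first", "only" and "open" are said of these compounds alone.

Compounds 1, 2 and 3 share one core, shown first in compound 1 `COc1ccc(-c2ccc3c(c2)C(=O)C(=O)N3)cc1`. In a functional assay on HepG2 cells (Homo sapiens) for antiproliferative activity, read by MTT assay, with a stated time of 48 h (a lower number here means a stronger inhibitor, a higher number a weaker inhibitor), compound 1 gives 960 nM. Compound 2 `COc1ccc(-c2ccc3c(c2)C(=O)C(=O)N3c2ccc(OC)cc2)cc1` carries a 4-methoxyphenyl on the amide-type nitrogen in the ring. In this assay compound 2 reaches only a limit of the assay, > 10000 nM. Compound 3 `COc1ccc(-c2ccc3c(c2)C(=O)C(=O)N3Cc2cccc(Cl)c2)cc1` gives 320 nM in this assay. The substituent on the nitrogen decides much here: an at least 10-fold higher number from compound 1 to compound 2 (1.01 log units; beyond the scatter), while a 3.0-fold lower number from compound 1 to compound 3 (0.48 log units; beyond the scatter) and an at least 31-fold lower number from compound 2 to compound 3 (1.49 log units; beyond the scatter). Compound 3 therefore stands at the lowest of the two plain numbers, with compound 1 nearest at a higher one; compound 2 sits at a limit, (the limit of > 10000 nM in this assay, at which 1 of the 3 values shown sits).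

Compound 4 `COc1ccc(-c2ccc3c(c2)C(=O)C(=O)N3Cc2ccc(C(F)(F)F)cc2)cc1` keeps the benzyl arrangement of compound 3 and changes only the ring it carries: 4-(trifluoromethyl)phenyl in place of 3-chlorophenyl on a saturated chain carbon bound to an amide-type nitrogen in a ring. Going by the values given here, none of the measured steps alters a group on that saturated chain carbon; all three exchange what sits directly on the nitrogen, and they are large or modest. So no measured step bears directly on this change, and the expected step is a 1.3-fold higher number from compound 3 to compound 4 (0.10 log units; within the scatter), within the scatter. Compound 4 is expected to give about 400 nM, in the range 150 nM to 1200 nM.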

Compound 4, half-maximal inhibitory concentration: 380 nM
Compound 4: the middle estimate sits 1.1-fold (0.02 log units) above what was measured, within the range that was stated.
By their numbers in this assay, from the lowest: compounds 3 and 4 (each within the scatter of the next); then compound 1. At a limit, above all of these: compound 2.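

In this assay, going by these compounds alone, the ring carried on the saturated chain carbon bound to the amide-type nitrogen is now exchanged for the first time, and the result is a 1.2-fold higher number from compound 3 to compound 4 (0.07 log units; within the scatter). The earlier steps shown here all changed what sits directly on the nitrogen and moved the number beyond the scatter, whereas this exchange of 3-chlorophenyl for 4-(trifluoromethyl)phenyl leaves compound 3 and compound 4 indistinguishable in this assay, even though both the group on the ring and its place on the ring differ. Nothing measured here gives a cause for this outcome.

Since the group and its place on the ring change together in this one step, the compounds shown cannot separate the two, and a pair such as 3-chlorophenyl and 4-chlorophenyl would be needed to do so. They also leave open whether the same holds for a ring carrying an amine or a carboxylic acid, or for a longer chain between the nitrogen and the ring.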